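A few compounds are considered here, and "the series" means these few. Any claim that something is new, unique, unknown or untested is made for them only; others in the source may bear on it.

Compound 2 `CCOC(=O)c1cnc(-c2ccc(C)s2)nc1NN1C(=O)C=C(C)C1=O` gives 200 nM in a functional assay on Jurkat cells for inhibition of nuclear factor NF-kappa-B complex (Homo sapiens) (a higher number here means a weaker inhibitor, a lower number a stronger inhibitor), the lowest of the two numbers measured; compound 1 `CCOC(=O)c1cnc(CC)nc1NN1C(=O)C=C(C)C1=O` gives 10000 nM. For the measured compounds named here, the one measured step, a 50-fold lower number from compound 1 to compound 2 (1.70 log units; beyond the scatter), is large and bears directly on the change at hand. Compound 3 `CCOC(=O)c1cnc(C2CC2)nc1NN1C(=O)C=C(C)C1=O` differs from compound 2 by cyclopropyl in place of 5-methylthiophen-2-yl on an aromatic carbon, which places a small saturated group where compound 1 carried ethyl. Compound 3 is therefore expected to move back toward compound 1 by about a 25-fold higher number from compound 2 to compound 3 (1.40 log units; beyond the scatter). The estimate for compound 3 in this assay is 5000 nM, in a range from 1500 nM to 20000 nM.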

Compound 3, half-maximal inhibitory concentration: 1000 nM
For compound 3 the middle estimate is 5.0-fold (0.70 log units) above the measured one; the whole stated range lies above it.
By their numbers in this assay, from the lowest: compound 2; then compound 3; then compound 1.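

In this assay, cyclopropyl in place of ethyl at the position between two ring nitrogen atoms already gives a 10-fold lower number from compound 1 to compound 3 (1.00 log units; beyond the scatter), so a gain over ethyl here does not require an aromatic ring. Yet the 5-methylthiophen-2-yl group keeps an edge, with a 5.0-fold higher number from compound 2 to compound 3 (0.70 log units; beyond the scatter), which places the three groups in a graded order. Nothing measured here explains that order. Whether the thiophene ring or its methyl carries the remaining difference stays open, since the compounds shown do not separate them. Phenyl, unsubstituted thiophen-2-yl or a longer chain such as butyl would help to settle this.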